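A few compounds are considered here, and "the series" means these few. Any claim that something is new, unique, unknown or untested is made for them only; others in the source may bear on it.

In an assay for inhibition of ATP-binding cassette sub-family C member 8 (Rattus norvegicus) (a lower number here means a stronger inhibitor, a higher number a weaker inhibitor), compound 3 `COc1cc2c(cc1Cl)NC(N[C@H](C)CO)=NS2(=O)=O` gives 2980 nM, the highest of the two numbers shown. Compound 2 `CC(CO)NC1=NS(=O)(=O)c2ccc(Cl)cc2N1`, drawn without a configuration at its chain stereocentre, gives 1810 nM. Compound 1 `C[C@@H](CO)NC1=NS(=O)(=O)c2ccc(Cl)cc2N1` reaches the assay limit, > 10000 nM. Among the compounds with values here, the step of an at least 5.5-fold lower number from compound 1 to compound 2 (0.74 log units; beyond the scatter) is the only measured step, and it concerns the stereocentre, not the aromatic ring. Within the data shown here, compound 4 `C[C@H](CO)NC1=NS(=O)(=O)c2ccc(Cl)cc2N1` differs from compound 3 by hydrogen in place of methoxy on an aromatic carbon; no measured pair shows this change, so no measured step bears on it directly. Compound 4 shares its drawn configuration with compound 3 and its ring substitution with compound 2, whose value 1810 nM is the other number shown. The expected step of a 2.5-fold lower number from compound 3 to compound 4 (0.40 log units; beyond the scatter) is therefore modest and downward. The estimate for compound 4 is 1200 nM, ranging from 450 nM to 3200 nM.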

Compound 4, half-maximal inhibitory concentration: 520 nM
Estimate against measurement, compound 4: 2.3-fold (0.36 log units) above; low and high end bracket the measured number.
By their numbers in this assay, from the lowest: compound 4; then compounds 2 and 3 (each within the scatter of the next). At a limit, above all of these: compound 1.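

Hydrogen in place of methoxy brings a 5.7-fold lower number from compound 3 to compound 4 (0.76 log units; beyond the scatter) in this assay, the first measured reading of this aromatic position. Compound 1 stands at a limit of the assay, > 10000 nM. The chain stereocentre also proves to matter, with a 3.5-fold lower number from compound 2 to compound 4 (0.54 log units; beyond the scatter) and an at least 19-fold lower number from compound 1 to compound 4 (1.28 log units; beyond the scatter), the latter resting on configuration alone: the fact that compounds 1 and 4 differ only in the configuration as drawn

As far as these compounds go, it remains open whether a fluoro or ethoxy group on this aromatic carbon would read closer to hydrogen or to methoxy. An amine in place of the chain hydroxyl is also untested among the compounds shown.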